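Swapping the group on a carbonyl carbon

This account rests on a few compounds, and the source may have more. Where it says the series, first, only, none or still open, it means among the compounds named here.

- Compound 1 `CC(C)n1ncc2c(C(=O)Nc3ncccn3)cc(-c3cccs3)nc21`: 75000 nM
- Compound 2 `CC(C)n1ncc2c(C(=O)N3CCc4cccnc43)cc(-c3cccs3)nc21`: 50000 nM

In an ADME assay on LLC-MK2 cells (Macaca mulatta) for cytotoxicity, read by spectrophotometry and crystal violet staining, with a stated time of 4 days (on this read-out lower numbers stand for higher toxicity in this test and higher numbers for lower toxicity in this test), compound 2 gives 50000 nM, which lies within the usual scatter of compound 1, so these two numbers cannot be ranked. Compound 3 `CC(C)n1ncc2c(C(=O)Nc3ccc(F)cc3F)cc(-c3cccs3)nc21` has not been measured yet. It differs from compound 2 by a group of 9 heavy atoms (6 carbon, 1 nitrogen, 2 fluorine; one six-membered aromatic ring of carbon only) in place of a group of 9 heavy atoms (7 carbon, 2 nitrogen; one five-membered non-aromatic ring with 1 hetero atom, one six-membered aromatic ring with 1 hetero atom), on a carbonyl carbon. The group that enters is (2,4-difluorophenyl)amino.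

For the measured compounds named here, only one measured step bears on this change: a 1.5-fold lower number from compound 1 to compound 2 (0.18 log units; within the scatter). That step also exchanges the group on the carbonyl carbon and stays within the scatter. It is a limited guide, since neither measured group on that carbonyl carbon holds fluorine or an aromatic ring of carbon only. With so little evidence, no change beyond the scatter is expected, though the range has to stay wide. The estimated step is a 1.1-fold lower number from compound 2 to compound 3 (0.05 log units; within the scatter). In this assay, the estimated value for compound 3 is 45000 nM, with an expected range from 18000 nM to 110000 nM.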

Compound 3, half-maximal cytotoxic concentration: > 200000 nM
Compound 3 was reported as a limit; the forecaster's own chance of this, stated with the estimate: 15%; middle value at least 4.4-fold (0.64 log units) from the limit.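

Until now, the two groups on the carbonyl carbon gave numbers that could not be ranked, so nothing showed that this position could move the read-out in this assay. Placing (2,4-difluorophenyl)amino there gives an at least 4.0-fold higher number from compound 2 to compound 3 (0.60 log units; beyond the scatter), and 2,4-difluorophenyl in place of pyrimidin-2-yl on an amide-type nitrogen gives an at least 2.6-fold higher number from compound 1 to compound 3 (0.42 log units; beyond the scatter), so on this read-out, where a higher number stands for lower toxicity in this test, the group at this position can make a difference beyond the scatter. The reading for compound 3 is a limit of the assay and not a number: the limit of > 200000 nM in this assay, at which 1 of the 3 values shown sits.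

The compounds shown leave open whether the fluorine atoms or the aromatic ring of carbon only goes with this step, a question that a plain phenyl on the same amide-type nitrogen would address. They also leave open whether a saturated ring such as morpholine on the carbonyl carbon, or a carboxylic acid on the phenyl ring, would give a similarly high number.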